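This account rests on a few compounds, and the source may have more. Where it says the series, first, only, none or still open, it means among the compounds named here.

Measured so far:
compound 1 `CC(C)(C)C1=C(C(=O)O)N2C(=O)[C@H](CO)[C@H]2O1`: in an ADME assay, in phosphate buffer, at 28 degrees C, at pH 7.0 (a higher number here means that the compound lasts longer, a lower number that the compound disappears faster), compound 1 gives 5 h
compound 2 `CC(C)(C)C1=C(C(=O)O)N2C(=O)[C@H]([C@H](O)c3ccccc3)[C@H]2O1`: in this assay compound 2 gives 7 h

Going by the values given here, compound 2 carries the larger of the two numbers, but the two values lie within the scatter of each other, as the single step shows: a 1.4-fold higher number from compound 1 to compound 2 (0.15 log units; within the scatter).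

Compound 3 `Cn1cc([C@@H](O)[C@H]2C(=O)N3C(C(=O)O)=C(C(C)(C)C)O[C@H]23)nn1` differs from compound 2 in one place: 1-methyl-1H-1,2,3-triazol-4-yl in place of phenyl on a saturated chain carbon bound to an oxygen on a saturated carbon and a saturated ring carbon. Among the compounds with values here, no measured step exchanges one aromatic ring for another at this position. Within the data shown here, the only step, a 1.4-fold higher number from compound 1 to compound 2 (0.15 log units; within the scatter), concerns the introduction of the phenyl itself and stayed within the scatter. The data therefore give no ground to expect a step beyond the scatter in this assay in either direction. Compound 3 is expected to give about 6 h in this assay, with a range from 3 h to 12 h. The expected step from compound 2 is a 1.2-fold lower number from compound 2 to compound 3 (0.07 log units; within the scatter).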

Compound 3, half-life: 6.8 h
Compound 3: the middle estimate sits 1.1-fold (0.05 log units) below what was measured; the range from low to high includes it.
By their numbers in this assay, from the lowest: compounds 1, 3 and 2 (each within the scatter of the next).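

Replacing the ring of carbon only with a five-membered aromatic ring with 3 hetero atoms, which brings 3 hydrogen-bond acceptors where phenyl has none, gives in this assay a 1.0-fold lower number from compound 2 to compound 3 (0.01 log units; within the scatter), the first aromatic-for-aromatic exchange read at this position. Measured against hydrogen, 1-methyl-1H-1,2,3-triazol-4-yl gives a 1.4-fold higher number from compound 1 to compound 3 (0.13 log units; within the scatter), so it stays within the scatter just as phenyl does with a 1.4-fold higher number from compound 1 to compound 2 (0.15 log units; within the scatter). Across compounds 1, 2 and 3, hydrogen, phenyl and 1-methyl-1H-1,2,3-triazol-4-yl at this position therefore cannot be told apart in this assay. No available evidence bears on this result. Still open, as far as these compounds go, is what an amine, a carboxylic acid or a longer chain would give at this position, and whether any group placed here produces a step beyond the scatter.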